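A few compounds are considered here, and "the series" means these few. Any claim that something is new, unique, unknown or untested is made for them only; others in the source may bear on it.

Working notes on a small set of purine-derived alkylating agents tested in a functional assay on OVCAR-3 cells (Homo sapiens) for cytotoxicity, read by sulforhodamine B assay, with a stated time of 48 h; on this read-out lower numbers stand for stronger inhibition of growth and higher numbers for weaker inhibition of growth.

Compound 1 `ClCc1ccc(Cn2cnc3c(Cl)ncnc32)cc1` gives 1380 nM in this assay. Compound 2 `Nc1nc(Cl)c2ncn(Cc3ccc(CCl)cc3)c2n1` carries the change amino in place of hydrogen on an aromatic carbon and gives 2140 nM; the step of a 1.6-fold higher number from compound 1 to compound 2 (0.19 log units; within the scatter). Compound 3 `ClCc1ccccc1Cn1cnc2c(Cl)ncnc21` gives 1410 nM; how its core differs from that of compound 1 is not broken down here, and the two values lie within the scatter of each other.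

Compound 4 `Nc1nc(Cl)c2ncn(Cc3ccccc3CCl)c2n1` is not yet measured. It differs from compound 3 by amino in place of hydrogen on an aromatic carbon, the same change as from compound 1 to compound 2, at a place described in identical words. Among the measured compounds shown here, the expected step of a 1.6-fold higher number from compound 3 to compound 4 (0.19 log units; within the scatter) rests on the one earlier instance, a 1.6-fold higher number from compound 1 to compound 2 (0.19 log units; within the scatter), with no second case to check it against. On that basis compound 4 is estimated at 2200 nM, with a plausible span from 1100 nM to 4500 nM.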

Compound 4, concentration for 50% growth inhibition: 3390 nM
The estimate for compound 4 lay 1.5-fold (0.19 log units) below the measured number, and the stated range covers the measured number.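

In this assay amino in place of hydrogen on an aromatic carbon brings a 2.4-fold higher number from compound 3 to compound 4 (0.38 log units; beyond the scatter) as the second case of this change. With only two cases, one of them within the scatter on its own, the series does not fix a size for the step or say anything about cores beyond these two. The change carries from the core of compound 1 to the core of compound 3 in the same direction, toward a higher number, and the two steps do not differ beyond the scatter: the same change on two cores in this assay, a 1.6-fold higher number (0.19 log units; within the scatter) from compound 1 to compound 2 and a 2.4-fold higher number (0.38 log units; beyond the scatter) from compound 3 to compound 4, 1.6-fold (0.19 log units) apart, within the scatter of two such steps

The compounds shown leave open whether a methylamino, dimethylamino or hydroxyl group in the same place would behave as amino does. They also leave open what a methoxy group or a longer chain would do in place of the chloro group.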